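Losing the 3-methoxybenzyl group from compound 3

The source may hold more compounds than are shown below. What is called first, only, known or untested is meant among the compounds shown, and "the series" means these compounds.

Measured in a functional assay on cells (T-cell line, Homo sapiens) for inhibition; on this read-out lower numbers stand for stronger inhibition and higher numbers for weaker inhibition:
- compound 1 `Clc1ccc(CCCN2CCC(COC(c3ccccc3)c3ccccc3)CC2)cc1` gives 500 nM
- compound 2 `Cc1ccc(CCCN2CCC(COC(c3ccccc3)c3ccccc3)CC2)cc1` gives 200 nM
- compound 3 `COc1cccc(CCCN2CCC(COC(c3ccccc3)c3ccccc3)CC2)c1` gives 1500 nM

Compound 3, at 1500 nM, is the weakest inhibitor of the three. The change to compound 4 `CCN1CCC(COC(c2ccccc2)c2ccccc2)CC1` is hydrogen in place of 3-methoxybenzyl on a saturated chain carbon, two bonds along the chain from an amine nitrogen in a ring. The closest evidence comes from swapping one aromatic group for another: a 3.0-fold higher number from compound 1 to compound 3 (0.48 log units; beyond the scatter), and a 7.5-fold higher number from compound 2 to compound 3 (0.88 log units; beyond the scatter). Within the data shown here, no measured step removes the aromatic group altogether, so this is an extrapolation. A step of similar size toward a higher number is expected in this assay. The estimated step is a 4.0-fold higher number from compound 3 to compound 4 (0.60 log units; beyond the scatter). Compound 4 is expected at 6000 nM, with an estimated range of 1500 nM to 25000 nM.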

Compound 4, half-maximal inhibitory concentration: > 20000 nM
Compound 4: no number, only a limit (the forecaster's own chance of this, stated with the estimate: 30%); middle value at least 3.3-fold (0.52 log units) away from the limit.
By their numbers in this assay, from the lowest: compound 2; then compound 1; then compound 3. At a limit, above all of these: compound 4.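

In this assay compound 4 gives only a limit, > 20000 nM. Earlier changes only exchanged one aromatic group for another, whereas removing the substituted benzyl group outright gives an at least 13-fold higher number from compound 3 to compound 4 (1.12 log units; beyond the scatter), an at least 100-fold higher number from compound 2 to compound 4 (2.00 log units; beyond the scatter) and an at least 40-fold higher number from compound 1 to compound 4 (1.60 log units; beyond the scatter). Among these compounds, then, having a benzyl group at this position matters more for inhibition than which of the three substituted benzyl groups is present.

A cyclohexylmethyl group in the same place would show whether the ring must be aromatic. A plain benzyl group would show whether any substituent on that ring is needed.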